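The compounds below may be only part of what the source reports. "The series", "measured", "known", "first", "only" and "open" are said of these compounds alone.

In an ADME assay on cells for inhibition of Intestinal-type alkaline phosphatase (Homo sapiens), read by luminescence, with stated times of 7 min and 20 min (on this read-out higher numbers stand for weaker inhibition and lower numbers for stronger inhibition), three compounds have been measured so far:

compound 1 `C=CCNc1nn2c(=O)cc(C(F)(F)F)nc2s1` gives 890 nM;
compound 2 `CCCCCNc1nn2c(=O)cc(C(F)(F)F)nc2s1` gives 760 nM;
compound 3 `CN(C)CCNc1nn2c(=O)cc(C(F)(F)F)nc2s1` gives 3750 nM.

Compound 3 stands at the highest number of the three, so it is the weakest inhibitor of this set. The gap is clear both ways: a 4.2-fold higher number from compound 1 to compound 3 (0.62 log units; beyond the scatter) and a 4.9-fold higher number from compound 2 to compound 3 (0.69 log units; beyond the scatter), each beyond the scatter. Between compounds 1 and 2 the picture is flat, a 1.2-fold lower number from compound 1 to compound 2 (0.07 log units; within the scatter), so swapping one plain chain for another on the nitrogen has not mattered.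

Compound 4 `O=c1cc(C(F)(F)F)nc2sc(-c3ccccc3F)nn12` changes the same position much more sharply: 2-fluorophenyl in place of (2-(dimethylamino)ethyl)amino on an aromatic carbon. The whole nitrogen-linked chain leaves, and an aromatic ring enters in its place. The two steps that bear on this are those into compound 3, which show that carrying the dimethylamino group on the chain goes with the higher number. Taking that group away should therefore be expected to bring the number down again, but no measured step covers an aromatic ring at this position, so the size is uncertain.

Compound 4 is estimated at 1500 nM, within 350 nM to 7000 nM, which is expected to mean a 2.5-fold lower number from compound 3 to compound 4 (0.40 log units; beyond the scatter).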

Compound 4, half-maximal inhibitory concentration: > 100000 nM
Compound 4 was reported as a limit (the forecaster's own chance of this, stated with the estimate: 10%); middle value at least 66-fold (1.82 log units) away from the limit.
By their numbers in this assay, from the lowest: compounds 2 and 1 (each within the scatter of the next); then compound 3. At a limit, above all of these: compound 4.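

In this assay compound 4 stands only as a limit, > 100000 nM, and not as a measured number: the limit of > 100000 nM in this assay, at which 1 of the 4 values shown sits.

Even so, replacing each of the nitrogen-linked chains with 2-fluorophenyl on this aromatic carbon gives a large step beyond the scatter, whichever chain leaves: an at least 26-fold higher number from compound 3 to compound 4 (1.42 log units; beyond the scatter), an at least 130-fold higher number from compound 2 to compound 4 (2.11 log units; beyond the scatter) and an at least 110-fold higher number from compound 1 to compound 4 (2.05 log units; beyond the scatter). The earlier compounds shown here kept the nitrogen link and varied only the chain on it, with steps that were flat or modest, so only now is it clear that this position can move the number much further when the whole linked chain is replaced by an aromatic ring.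

Compound 4 loses the nitrogen link and gains the ring in one change, so the compounds shown cannot tell which of the two goes with the large step. A phenylamino group would keep the nitrogen together with an aromatic ring, and a plain phenyl ring would show whether the fluorine plays any part.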